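A few compounds are considered here, and "the series" means these few. Any claim that something is new, unique, unknown or untested is made for them only; others in the source may bear on it.

In an ADME assay on NIH3T3 cells (Mus musculus) for cytotoxicity (on this read-out higher numbers stand for an effect only at larger amounts of compound and lower numbers for an effect already at smaller amounts), three compounds have been measured so far. Compound 1 `Cc1cc([N+](=O)[O-])ccc1Nc1cccc(Cn2ccnc2)c1` gives > 100000 nM, which is a limit of the assay and not a number. Compound 2 `Clc1ccc(CCOc2cccc(Cn3ccnc3)c2)cc1` gives 71100 nM, and compound 3 `Cc1cc(Oc2cccc(Cn3cncn3)c2)cc(C)c1Cl` gives 75900 nM. These last two numbers lie within the usual scatter of each other, so the assay cannot separate compound 3 from compound 2.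

Compound 4 `Cc1cc(Oc2cccc(Cn3cnnc3)c2)cc(C)c1Cl` contains the same atoms as compound 3, joined differently: 4H-1,2,4-triazol-4-yl in place of 1H-1,2,4-triazol-1-yl on a saturated chain carbon bound to an aromatic carbon. The triazole ring stays on the same saturated chain carbon bound to an aromatic carbon, but it is now attached as 4H-1,2,4-triazol-4-yl.

Within the data shown here, no measured pair shows this swap on its own, so the expectation rests on a weak basis. Compound 2 at 71100 nM and compound 3 at 75900 nM differ in more than one place, yet their numbers stay within the scatter. No step beyond the scatter is expected in this assay, and the estimated change is a 1.1-fold higher number from compound 3 to compound 4 (0.02 log units; within the scatter). For compound 4 the expected value is 80000 nM, with an estimated range from 40000 nM to 100000 nM.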

Compound 4, half-maximal effective concentration: > 100000 nM
Compound 4 ended at the assay's limit; the forecaster's own chance of this, stated with the estimate: 35%; at least 1.2-fold (0.09 log units) between middle value and limit.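

Moving the attachment of the triazole ring, with 4H-1,2,4-triazol-4-yl in place of 1H-1,2,4-triazol-1-yl, is the only change among the compounds shown that can be followed on its own, and in this assay it gives an at least 1.3-fold higher number from compound 3 to compound 4 (0.11 log units; that floor lies within the scatter). The swap therefore does not bring the effect down to smaller amounts of compound, even though the atoms stay the same and only their joining differs. Whether it truly raises the number cannot be said, because compound 4 gives a limit and not a number: the limit of > 100000 nM in this assay, at which 2 of the 4 values shown sit.

Still open, going by these compounds, is whether this swap would give a step beyond the scatter on another core. Also open, on these data alone, is what an amine or a carboxylic acid would do on the saturated chain carbon bound to an aromatic carbon, in place of the triazole ring.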